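Trimming isopropyl to methyl on the shared core

The compounds below may be only part of what the source reports. "The series", "measured", "known", "first", "only" and "open" are said of these compounds alone.

Among the compounds with values here, in a functional assay on MCF7 cells (Homo sapiens) for cytotoxicity, read by MTT assay, with a stated time of 48 h (a higher number here means a weaker inhibitor, a lower number a stronger inhibitor), compound 3 (`CC(C)n1c(/C=C2/C(=O)Nc3ccc(Cl)cc32)nc2ccccc21`) gives 24000 nM as the only exact number so far. Compound 2 (`Cn1c(/C=C2/C(=O)Nc3ccc(Br)cc32)nc2ccccc21`) reads > 50000 nM and that is a limit of the assay, not a number. Compound 1 (`Cn1c(/C=C2/C(=O)Nc3ccc([N+](=O)[O-])cc32)nc2ccccc21`) has the entry "not determined" (no result reported) and offers no comparison. Compound 4 (`Cn1c(/C=C2/C(=O)Nc3ccc(Cl)cc32)nc2ccccc21`) differs from compound 3 by methyl in place of isopropyl on an aromatic nitrogen. Within the data shown here, no measured pair shows this change alone. With compound 2, which also carries methyl, at > 50000 nM as a limit, a modest move toward a weaker reading is expected in this assay and not a large one. The estimated change is a 1.7-fold higher number from compound 3 to compound 4 (0.22 log units; within the scatter) by this reasoning. Compound 4 is estimated at 40000 nM with an expected range from 18000 nM to 90000 nM in this assay.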

Compound 4, half-maximal inhibitory concentration: > 50000 nM
Compound 4: no number, only a limit (the forecaster's own chance of this, stated with the estimate: 45%); middle value at least 1.2-fold (0.09 log units) away from the limit.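

Methyl in place of isopropyl on an aromatic nitrogen now stands alone for the first time, and in this assay it gives an at least 2.0-fold higher number from compound 3 to compound 4 (0.31 log units; beyond the scatter). On this position, then, the isopropyl compound keeps a readable value while the methyl compound does not. The step from compound 2 to compound 4, chloro in place of bromo on an aromatic carbon, cannot be read, because both values are limits: the limit of > 50000 nM in this assay, at which 2 of the 4 values shown sit.

As far as these compounds go, how far the methyl compound lies past that limit stays open. So does whether a longer chain, or a chain ending in an amine, on this nitrogen would give a lower number than compound 3.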